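N-methylation of the indole in a hydrazone series

This account rests on a few compounds, and the source may have more. Where it says the series, first, only, none or still open, it means among the compounds named here.

Measured compounds:
compound 1 `COc1ccc2c(c1)c(/C=N\NC(=O)c1cn(C)c3ccccc13)cn2Cc1ccc(Cl)cc1` — 93000 nM
compound 2 `COc1ccc2c(c1)c(/C=N\NC(=O)c1c[nH]c3ccccc13)cn2Cc1ccc(Cl)cc1` — 50000 nM
compound 3 `COc1ccc(Cn2cc(/C=N\NC(=O)c3c[nH]c4ccccc34)c3ccc(F)cc32)cc1` — 16200 nM

All three were tested in a functional assay on DU-145 cells (Homo sapiens) for cytotoxicity; a higher number here means a weaker inhibitor, a lower number a stronger inhibitor. Compound 1 gives 93000 nM, compound 2 gives 50000 nM and compound 3 gives 16200 nM, the lowest of the three numbers. The two cores differ in more than one place, so the difference between the core of compound 2 and the core of compound 3 is not broken down here; the numbers of compound 2 and compound 3 stand beyond the scatter of each other.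

Within the core of compound 2, one change is documented: methyl in place of hydrogen on an aromatic nitrogen. Its effect in this assay is a 1.9-fold higher number from compound 2 to compound 1 (0.27 log units; within the scatter), a step that stays within the scatter.

Compound 4 `COc1ccc(Cn2cc(/C=N\NC(=O)c3cn(C)c4ccccc34)c3ccc(F)cc32)cc1` has not yet been measured. Among the measured compounds shown here, it differs from compound 3 by methyl in place of hydrogen on an aromatic nitrogen, the same kind of change as the one from compound 2 to compound 1, made at the same place of the same ring system. Since that earlier step gave a 1.9-fold higher number from compound 2 to compound 1 (0.27 log units; within the scatter), a step of similar size is expected here: the estimated step is a 1.9-fold higher number from compound 3 to compound 4 (0.27 log units; within the scatter), which rests on a single prior pair and so carries a wide band. On that basis compound 4 is expected to give about 30000 nM in this assay, most likely between 12000 nM and 80000 nM.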

Compound 4, half-maximal inhibitory concentration: 15200 nM
For compound 4 the middle estimate is 2.0-fold (0.30 log units) above the measured one, and the stated range covers the measured number.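

In this assay, methyl in place of hydrogen on the aromatic nitrogen gives a 1.1-fold lower number from compound 3 to compound 4 (0.03 log units; within the scatter), so on this core the change leaves no effect that can be told from the scatter. Set beside the same change on the other core, the step does not differ: the same change on two cores in this assay, a 1.9-fold higher number (0.27 log units; within the scatter) from compound 2 to compound 1 and a 1.1-fold lower number (0.03 log units; within the scatter) from compound 3 to compound 4, 2.0-fold (0.30 log units) apart, within the scatter of two such steps The change 1H-indol-3-yl to 1-methyl-1H-indol-3-yl therefore carries across these two cores as a step within the scatter each time, and the opposite signs of the two steps carry no meaning; this rests on only two pairs, in one assay, and does not show that the change would stay this small on a further core or that the hydrogen on that nitrogen is dispensable in general.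

Still open, from the compounds shown here alone, is how the number responds when that nitrogen carries something other than methyl, such as an ethyl group, a longer chain or a chain ending in an amine or a carboxylic acid. Also open is which of the several differences between the two cores accounts for the gap in their numbers, since no single-place step links one core to the other.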